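A Propanoyl Ester in Place of Isopentyl

A few compounds are considered here, and "the series" means these few. Any claim that something is new, unique, unknown or untested is made for them only; others in the source may bear on it.

Measured in a functional assay on A549 cells (Homo sapiens) for cytotoxicity, with a stated time of 48 h; on this read-out lower numbers stand for stronger inhibition and higher numbers for weaker inhibition:
- Compound 1 `CC(C)CC(=O)Oc1ccc2oc(/C=C/[S+](C)[O-])cc(=O)c2c1`: 2300 nM
- Compound 2 `CC(C)CCOc1ccc2oc(/C=C/[S+](C)[O-])cc(=O)c2c1`: 1000 nM

Compound 2 holds the lower of the two numbers. Compound 3 `CCC(=O)Oc1ccc2oc(/C=C/[S+](C)[O-])cc(=O)c2c1` departs from it by propanoyl in place of isopentyl on an oxygen on an aromatic ring, with propanoyl in place of isopentyl on an oxygen on an aromatic ring. For the measured compounds named here, one measured step bears on this, the modest 2.3-fold lower number from compound 1 to compound 2 (0.36 log units; beyond the scatter), where isopentyl replaced isobutylcarbonyl at that place. The new change runs the opposite way, so a modest rise in the number is expected in this assay. The expected shift is a 2.5-fold higher number from compound 2 to compound 3 (0.40 log units; beyond the scatter). Compound 3 is estimated at 2500 nM, within a range of 1200 nM to 5000 nM.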

Compound 3, half-maximal inhibitory concentration: 2400 nM
The estimate for compound 3 lay 1.0-fold (0.02 log units) above the measured number, within the range that was stated.
By their numbers in this assay, from the lowest: compound 2; then compounds 1 and 3 (each within the scatter of the next).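

In this assay, the step of a 2.4-fold higher number from compound 2 to compound 3 (0.38 log units; beyond the scatter) is about as large as the earlier ether-to-ester step, now seen with a second ester. Methyl in place of isopropyl on a saturated chain carbon bound to a carbonyl carbon gives a 1.0-fold higher number from compound 1 to compound 3 (0.02 log units; within the scatter), so propanoyl and isobutylcarbonyl are not told apart here, and both esters stand apart from the isopentyl ether of compound 2. Nothing measured here accounts for this. Still open, from the compounds shown here alone, is whether a shorter ether such as propyl would match compound 2, and what a carbamate would do on this oxygen.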